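Notes on the step from compound 2 to compound 3

A few compounds are considered here, and "the series" means these few. Any claim that something is new, unique, unknown or untested is made for them only; others in the source may bear on it.

Measured in an ADME assay on HEK293 cells (Homo sapiens) for cytotoxicity, read by CCK-8 assay, with a stated time of 48 h; on this read-out higher numbers stand for weaker inhibition and lower numbers for stronger inhibition:
- compound 1 `COc1ccc(/C=C\c2cc(OC)c(OC)c(OC)c2)cc1OCc1ccc(CN2CC[C@H](C(=O)O)C2)cc1`: > 50000 nM, a limit
- compound 2 `COc1ccc(/C=C\c2cc(OC)c(OC)c(OC)c2)cc1OCc1ccc(CN2CC[C@H](O)C2)cc1`: > 50000 nM, a limit

Compound 2 gives no number, only the limit > 50000 nM. Compound 3 `COc1ccc(/C=C\c2cc(OC)c(OC)c(OC)c2)cc1OCc1ccc(CN2CCCCC2C(=O)NCCN)cc1` is not yet measured and differs from compound 2 at one place: 2-((2-aminoethyl)carbamoyl)piperidin-1-yl in place of 3-hydroxypyrrolidin-1-yl on a saturated chain carbon bound to an aromatic carbon.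

Among the compounds with values here, one measured step bears on this change only loosely: a step that the two limits leave unreadable from compound 1 to compound 2. It concerns hydroxy and carboxy on a saturated ring carbon, and it offers no size to carry over. Within the data shown here, no step of readable size can therefore be derived for this assay. A further limit is the expected outcome because of the limit of > 50000 nM in this assay, at which 2 of the 2 values shown sit. If a number does appear, the expected direction is towards stronger inhibition, though this remains untested in the series. The estimated change is a number no higher from compound 2 to compound 3 (the limit leaves the size open). For compound 3 the expected value is 50000 nM, with an estimated range from 15000 nM to 80000 nM.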

Compound 3, half-maximal inhibitory concentration: > 50000 nM
Compound 3 gave a limit, no number; the forecaster's own chance of this, stated with the estimate: 65%; the middle value sits exactly at the limit.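

In this assay compound 3 gives > 50000 nM, which is a limit and not a number. Compound 1 and compound 2 are also recorded only as limits, so no step among these three compounds can be read. The compounds shown leave open whether any group on the saturated chain carbon gives a measurable value in this assay.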